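The source may hold more compounds than are shown below. What is called first, only, known or untested is meant among the compounds shown, and "the series" means these compounds.

Of the compounds shown here, two have so far been tested in a functional assay on SJSA-1 cells (Homo sapiens) for inhibition, read by CCK-8 assay, with a stated time of 72 h, tested at 1 uM; on this read-out lower numbers stand for less inhibition and higher numbers for more inhibition at the one concentration tested (going by the name of the read-out). Compound 1, `COc1ccccc1N1C(=O)CSC1c1cc(F)cc(C(=O)O)c1`, gives 0% in this assay. Compound 2, `COc1cccc(OC)c1N1C(=O)CSC1c1cccc(C(=O)NCCCCc2ccccc2)c1`, gives 72% in this assay, the higher of the two numbers, with a gap to compound 1 well beyond the usual scatter. Compound 3, `O=C(NCCCCc1ccccc1)c1cccc(C2SCC(=O)N2c2ccccc2F)c1`, has not yet been measured. It differs from compound 2 in one place: 2-fluorophenyl in place of 2,6-dimethoxyphenyl on an amide-type nitrogen in a ring. For the measured compounds named here, no measured pair shows this change, so the size of its effect is open. A modest drop is expected, a step of a number 17 percentage points lower from compound 2 to compound 3 (beyond the scatter). Compound 3 is therefore estimated at 55%, within a range from 25% to 80%.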

Compound 3, a percentage reported as inhibition, at one concentration (the size of the read-out at that concentration, not a potency): 80%
Compound 3: the middle estimate sits 25 percentage points below what was measured; measured number inside the range.
By their numbers in this assay, from the lowest: compound 1; then compounds 2 and 3 (each within the scatter of the next).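

In this assay, putting 2-fluorophenyl in place of 2,6-dimethoxyphenyl on the amide-type nitrogen gives a number 8 percentage points higher from compound 2 to compound 3 (within the scatter) and so leaves the two compounds indistinguishable. At this position, then, the smaller group with no hydrogen-bond acceptors serves as well as the larger one with two, so those acceptors are not needed for this level of inhibition. No measurement is available to explain this match. As far as these compounds go, whether a plain phenyl or a pyridine ring would also hold this level remains open. A single tested concentration also leaves the potency of compound 2 and compound 3 unresolved.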